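A Smaller Acyl Group and Expected Cell Tolerance

This account rests on a few compounds, and the source may have more. Where it says the series, first, only, none or still open, it means among the compounds named here.

The study follows how much of each compound cultured cells tolerate, read as a toxicity assay on THP-1 cells (Homo sapiens) for inhibition; a lower number here means that less compound is tolerated, a higher number that more compound is tolerated. Compound 1 `COc1ccc(CNC(=O)NC(=O)c2ccc(F)cc2)cc1` reaches only a limit in this assay, > 50000 nM. Compound 2 `Cn1c(-c2cccc(C#N)c2)cnc1NC(=O)c1ncc[nH]1` likewise gives only a limit in this assay, > 50000 nM. Compound 3 `COc1ccc(-c2cnc(NC(=O)C3CCCC3)n2C)cc1` also stands at a limit in this assay, > 100000 nM, so no number is known for it. The values fall at the limit of > 50000 nM in this assay, at which 2 of the 3 values shown sit, and at the limit of > 100000 nM in this assay, at which 1 of the 3 values shown sits; every compound shown is tolerated up to where the assay stops counting.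

Compound 4 `COc1ccc(-c2cnc(NC(C)=O)n2C)cc1` differs from compound 3 in one place: methyl in place of cyclopentyl on a carbonyl carbon. Within the data shown here, no pair of measured compounds differs in one place, and the measured set offers no step of this kind to lean on. Among the measured compounds shown here, with every value so far at a limit, the step of a number no higher from compound 3 to compound 4 (the limit leaves the size open) is expected to be no larger than the usual scatter, in no particular direction. Compound 4 is therefore estimated to show 100000 nM in this assay, within a range from 50000 nM to 200000 nM, and most likely once more only a limit.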

Compound 4, half-maximal cytotoxic concentration: > 100000 nM
Compound 4: only a limit was reported; the forecaster's own chance of this, stated with the estimate: 90%; the middle value sits exactly at the limit.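

Among these compounds, compound 3 and compound 4 both stand only at a limit in this assay, so no step between them can be read. The compounds shown leave open at what concentration any of them stops being tolerated, and whether swapping cyclopentyl for methyl changes that concentration at all.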